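This account rests on a few compounds, and the source may have more. Where it says the series, first, only, none or still open, it means among the compounds named here.

In an ADME assay on HEK293 cells (Homo sapiens) for cytotoxicity, read by MTT assay, with a stated time of 48 h (on this read-out higher numbers stand for weaker inhibition and lower numbers for stronger inhibition), three compounds with a shared core have been measured, and they differ only in the group on a double-bonded chain carbon bound to a double-bonded ring carbon. Compound 1 `COc1ccc(/C=C2/S/C(=N/c3ccccc3)N(Cc3ccncc3)C2=O)cc1` gives 47900 nM, compound 2 `O=C1/C(=C\c2ccc([N+](=O)[O-])cc2)S/C(=N/c2ccccc2)N1Cc1ccncc1` gives 250000 nM and compound 3 `COc1cc(/C=C2/S/C(=N/c3ccccc3)N(Cc3ccncc3)C2=O)ccc1O` gives 67400 nM. Two steps place compound 3 on this scale: a 1.4-fold higher number from compound 1 to compound 3 (0.15 log units; within the scatter), and a 3.7-fold lower number from compound 2 to compound 3 (0.57 log units; beyond the scatter). Its number therefore matches that of compound 1 within the scatter and lies clearly under that of compound 2.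

Compound 4 `O=C1/C(=C\c2cccc(Cl)c2)S/C(=N/c2ccccc2)N1Cc1ccncc1` has not yet been measured. Its change is 3-chlorophenyl in place of 4-hydroxy-3-methoxyphenyl on a double-bonded chain carbon bound to a double-bonded ring carbon. Within the data shown here, no measured compound carries this new group, so the guides are the earlier swaps at the same place. One swap stayed within the scatter, while the nitro compound gave a 5.2-fold higher number from compound 1 to compound 2 (0.72 log units; beyond the scatter), a modest move and the exception among these steps. The expected result is therefore no change beyond the scatter, and the estimated step is a 1.2-fold higher number from compound 3 to compound 4 (0.07 log units; within the scatter). Compound 4 is expected at about 80000 nM, with an estimated range from 32000 nM to 200000 nM.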

Compound 4, half-maximal inhibitory concentration: 71800 nM
Estimate against measurement, compound 4: 1.1-fold (0.05 log units) above; the range from low to high includes it.
By their numbers in this assay, from the lowest: compounds 1, 3 and 4 (each within the scatter of the next); then compound 2.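

In this assay, the change to 3-chlorophenyl leaves the number within the scatter of both oxygen-bearing compounds (a 1.1-fold higher number from compound 3 to compound 4 (0.03 log units; within the scatter); a 1.5-fold higher number from compound 1 to compound 4 (0.18 log units; within the scatter)), so this position accepts a chlorine-bearing ring in place of 4-hydroxy-3-methoxyphenyl, even though the hydrogen-bond donor and both acceptors of that group are lost. Among these compounds, compound 2 remains the one compound set apart, now also from this new group (a 3.5-fold lower number from compound 2 to compound 4 (0.54 log units; beyond the scatter)), which makes its 4-nitrophenyl the sole exception among the four. No measurement here explains why the nitro compound differs from the other three.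

Going by these compounds, every group at this place is a substituted phenyl, so it remains open whether an amine on the ring, a carboxylic acid or a plain alkyl chain would keep the number. The other parts of the shared core are the same in all four compounds, so changes there cannot be judged.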